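This account rests on a few compounds, and the source may have more. Where it says the series, first, only, none or still open, it means among the compounds named here.

Compound 1 `CC(=O)Nc1ccc2oc(-c3cccc(C(F)(F)F)c3)c(O)c(=O)c2c1`: 1000 nM
Compound 2 `Nc1ccc2oc(-c3ccccc3)c(O)c(=O)c2c1`: 27000 nM
Compound 3 `COc1cccc(-c2oc3ccc(N)cc3c(=O)c2O)c1`: 2000 nM

These three values come from an ADME assay on THP-1 cells (Homo sapiens) for cytotoxicity, read by flow cytometry and propidium iodide staining, with a stated time of 72 h; a lower number here means a stronger inhibitor, a higher number a weaker inhibitor. In this assay, compound 3 `COc1cccc(-c2oc3ccc(N)cc3c(=O)c2O)c1` gives 2000 nM, which lies within the usual scatter of the value for compound 1, so the two cannot be told apart. Compound 2 stands clearly apart from both, with the highest number of the three.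

The next compound, compound 4 `Nc1ccc2oc(-c3cccc(C(F)(F)F)c3)c(O)c(=O)c2c1`, differs from compound 3 at one place: trifluoromethyl in place of methoxy on an aromatic carbon. In words, trifluoromethyl takes the place of methoxy on an aromatic carbon.

Going by the values given here, no measured step makes this exact exchange. The closest is a 14-fold lower number from compound 2 to compound 3 (1.13 log units; beyond the scatter), where methoxy replaces hydrogen on an aromatic carbon. That large step shows how much a single change on an aromatic carbon can matter here, but it does not tell how trifluoromethyl will compare with methoxy. Compound 1 offers a second clue. It also carries trifluoromethyl and gives 1000 nM, although the shared core differs elsewhere.

On this evidence, no step beyond the scatter is expected, and the estimated step is no change at the digits printed from compound 3 to compound 4 (within the scatter). For compound 4 the expected value is about 2000 nM. The estimated range for compound 4 runs from 600 nM to 7000 nM.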

Compound 4, half-maximal inhibitory concentration: 2000 nM
The estimate for compound 4 equals the measured number at the digits printed; low and high end bracket the measured number.
By their numbers in this assay, from the lowest: compounds 1, 3 and 4 (each within the scatter of the next); then compound 2.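

In this assay the exchange of methoxy for trifluoromethyl gives no change at the digits printed from compound 3 to compound 4 (within the scatter), so on this aromatic carbon the two groups cannot be told apart, although one brings oxygen and the other fluorine. Trifluoromethyl in place of hydrogen gives a 14-fold lower number from compound 2 to compound 4 (1.13 log units; beyond the scatter), the same large step as a 14-fold lower number from compound 2 to compound 3 (1.13 log units; beyond the scatter) with methoxy, so the large step from compound 2 is not tied to methoxy alone. Hydrogen in place of acetyl on the nitrogen gives a 2.0-fold higher number from compound 1 to compound 4 (0.30 log units; within the scatter), so this second change also leaves no difference that can be read. No measurement shown here explains why these two groups give the same number.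

As far as these compounds go, it remains open whether a nitrile, a carboxylic acid or an amine on the same aromatic carbon would give a number close to those of compound 3 and compound 4 or one closer to that of compound 2. From the compounds shown here alone, the acetyl comparison also rests on a single pair that carries trifluoromethyl, so it is unknown whether acetyl on the nitrogen would make as little difference alongside methoxy or hydrogen on that carbon.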